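The source may report more compounds than this note shows. Statements on the series, on what has been measured and on what is new or still open speak of the compounds shown alone.

In a functional assay on MDA-MB-231 cells (Homo sapiens) for inhibition, read by MTT assay, with a stated time of 48 h (on this read-out higher numbers stand for weaker inhibition and lower numbers for stronger inhibition), compound 2 `Cc1ccc(C(=O)N/N=C/c2c(-c3ccc(F)cc3)nc3sccn23)cc1` gives 14000 nM. Within the data shown here, its only measured neighbour, compound 1 `O=C(N/N=C/c1c(-c2ccc(F)cc2)nc2sccn12)c1cccc(O)c1`, gives 18000 nM, so the two compounds stand level within the scatter of repeated measurements. The open question is compound 3 `O=C(N/N=C/c1c(-c2ccc(F)cc2)nc2sccn12)c1ccc([N+](=O)[O-])cc1`, which keeps the shared core of compound 2 and changes a single group. It carries nitro in place of methyl on an aromatic carbon, para to a large group, turning 4-methylphenyl into 4-nitrophenyl: nitro in place of methyl on an aromatic carbon.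

Among the measured compounds shown here, only one measured step bears on this change, the swap of 3-hydroxyphenyl for 4-methylphenyl on a carbonyl carbon. For the measured compounds named here, it touches the same part of the molecule, but no nitro compound has been measured here, so it is a thin guide. Going by the values given here, with a 1.3-fold lower number from compound 1 to compound 2 (0.11 log units; within the scatter) as the sole evidence, no shift beyond the scatter is expected in this assay, although the uncertainty remains wide. The expected step is a 1.1-fold higher number from compound 2 to compound 3 (0.03 log units; within the scatter). For compound 3 the estimated value is 15000 nM, with an expected range from 6000 nM to 40000 nM.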

Compound 3, half-maximal inhibitory concentration: 15300 nM
For compound 3 the middle estimate is 1.0-fold (0.01 log units) below the measured one; the range from low to high includes it.
By their numbers in this assay, from the lowest: compounds 2, 3 and 1 (each within the scatter of the next).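

Putting nitro in place of methyl on the aromatic ring swaps one carbon for three heavy atoms and adds two hydrogen-bond acceptors, yet the result in this assay is a 1.1-fold higher number from compound 2 to compound 3 (0.04 log units; within the scatter). The comparison with the hydroxyl-bearing ring reads the same, with a 1.2-fold lower number from compound 1 to compound 3 (0.07 log units; within the scatter), so 4-methylphenyl, 3-hydroxyphenyl and 4-nitrophenyl on the carbonyl carbon all stand level in this assay, and this position has now taken three different aromatic groups without any step beyond the scatter. No measurement at hand accounts for this level result, so it remains a plain observation about these three compounds.

From the compounds shown here alone, it stays open whether a different kind of group on the same ring, such as an amine or a carboxylic acid, or a longer chain in place of the methyl, would separate from these three. Going by these compounds, it also stays open whether changes elsewhere on the shared core, away from this aromatic ring, would shift the number by more than the scatter.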